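Pyrazinyl Amide: Expected Step from Compound 3

The source may hold more compounds than are shown below. What is called first, only, known or untested is meant among the compounds shown, and "the series" means these compounds.

Measured in an assay on CHO cells with metabotropic glutamate receptor 5 (Homo sapiens) as the target; a lower number here means that less compound is needed, a higher number that more compound is needed for the effect:
compound 1, `O=C(Nc1cc(-c2ccccc2)nn1-c1ccccc1)c1ccc(F)c(F)c1`: 10 nM
compound 2, `O=C(Nc1cc(-c2ccccc2)nn1-c1ccccc1)c1ccccc1`: 40 nM
compound 3, `O=C(Nc1cc(-c2ccccc2)nn1-c1ccccc1)c1ccccn1`: 290 nM

Compound 3 stands highest of the three numbers; its nearest neighbour is reached by a 7.3-fold higher number from compound 2 to compound 3 (0.86 log units; beyond the scatter) and its furthest by a 29-fold higher number from compound 1 to compound 3 (1.46 log units; beyond the scatter). Compound 4, `O=C(Nc1cc(-c2ccccc2)nn1-c1ccccc1)c1cnccn1`, differs from compound 3 by pyrazin-2-yl in place of pyridin-2-yl on a carbonyl carbon. The step that bears most on this change is the earlier one, a 7.3-fold higher number from compound 2 to compound 3 (0.86 log units; beyond the scatter), where one ring nitrogen entering raised the number in this assay, while a 4.0-fold higher number from compound 1 to compound 2 (0.60 log units; beyond the scatter) shows the ring carrying the carbonyl is sensitive in this series. A second nitrogen is therefore expected to raise the number again, modestly, a 2.2-fold higher number from compound 3 to compound 4 (0.35 log units; beyond the scatter). Compound 4 is thus expected to give about 650 nM in this assay, estimated between 220 nM and 2200 nM.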

Compound 4, half-maximal effective concentration: 200 nM
Beside the measured number, compound 4's estimate is 3.3-fold (0.51 log units) above it, outside the stated range (below it).
By their numbers in this assay, from the lowest: compound 1; then compound 2; then compounds 4 and 3 (each within the scatter of the next).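

In this assay, pyrazin-2-yl and pyridin-2-yl on the carbonyl carbon cannot be told apart (a 1.5-fold lower number from compound 3 to compound 4 (0.16 log units; within the scatter)), so the second ring nitrogen does not repeat the step seen with the first. The gap to the phenyl amide stays beyond the scatter (a 5.0-fold higher number from compound 2 to compound 4 (0.70 log units; beyond the scatter)), and the gap to the 3,4-difluorophenyl amide remains large (a 20-fold higher number from compound 1 to compound 4 (1.30 log units; beyond the scatter)). Nothing available explains these steps.

Still open, on these data alone, is whether an amine or a fluorine on the pyrazin-2-yl ring would bring the number closer to that of compound 1 (10 nM).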